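This account rests on a few compounds, and the source may have more. Where it says the series, first, only, none or still open, it means among the compounds named here.

Compound 2 `Cn1c(=O)c2c(nc(COc3cccc(Br)c3)n2C)n(C)c1=O` gives 148 nM in an in vitro assay on cells for inhibition of Amine oxidase [flavin-containing] B (Homo sapiens), read by coupled enzyme assay, with a stated time of 20 min (a higher number here means a weaker inhibitor, a lower number a stronger inhibitor), the lowest of the three numbers recorded. Compound 3 `COc1cccc(OCc2nc3c(c(=O)n(C)c(=O)n3C)n2C)c1` gives 1960 nM in this assay, and compound 1 `Cn1c(=O)c2c(nc(CCSc3cccc(Br)c3)n2C)n(C)c1=O` gives 64100 nM. The only single-point step among these is a 13-fold higher number from compound 2 to compound 3 (1.12 log units; beyond the scatter), which concerns the substituent on the aromatic ring rather than where it sits. Compound 1 differs from compound 2 in more than one place, so its value is noted only as a much higher number.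

Compound 4 `Cn1c(=O)c2c(nc(COc3ccc(Br)cc3)n2C)n(C)c1=O` carries the change (4-bromophenyl in place of 3-bromophenyl on an oxygen on a saturated carbon); that is, 4-bromophenyl in place of 3-bromophenyl on an oxygen on a saturated carbon whose other neighbour is a saturated chain carbon. Within the data shown here, no measured step shifts a bromo between positions of the ring, so the outcome cannot be anchored to a recorded step of this kind. Since the bromo is kept, it is expected that compound 4 stays in the same region as compound 2, with a step of a 1.4-fold higher number from compound 2 to compound 4 (0.13 log units; within the scatter) that need not exceed the scatter. Compound 4 is therefore estimated at 200 nM, with a range of 60 nM to 700 nM.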

Compound 4, half-maximal inhibitory concentration: 189 nM
Beside the measured number, compound 4's estimate is 1.1-fold (0.02 log units) above it, and the stated range covers the measured number.
By their numbers in this assay, from the lowest: compounds 2 and 4 (each within the scatter of the next); then compound 3; then compound 1.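

In this assay, 4-bromophenyl in place of 3-bromophenyl on an oxygen on a saturated carbon gives a 1.3-fold higher number from compound 2 to compound 4 (0.11 log units; within the scatter), so the two bromo isomers, compound 2 and compound 4, cannot be told apart here. The earlier methoxy-for-bromo step, a 13-fold higher number from compound 2 to compound 3 (1.12 log units; beyond the scatter), now has a counterpart in a 10-fold lower number from compound 3 to compound 4 (1.02 log units; beyond the scatter), which places both bromo compounds well apart from compound 3. Nothing available bears on the reason for this result.

On these data alone, whether a chloro, a nitrile or a carboxylic acid in place of the bromo would leave a number close to that of compound 4, 189 nM, remains open. As far as these compounds go, compound 1 gives 64100 nM but differs from compound 2 in more than one place, so the share of the oxygen on the saturated carbon alone also remains open.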